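The source may hold more compounds than are shown below. What is called first, only, known or untested is meant among the compounds shown, and "the series" means these compounds.

Compound 1, `O=C(/C=C/C1=Cc2ccccc2OC1)c1ccc(F)cc1`: 65.6%
Compound 2, `O=C(/C=C/C1=Cc2ccccc2OC1)c1cccc(Cl)c1`: 51%
Compound 3, `O=C(/C=C/C1=Cc2ccccc2OC1)c1cccc(Br)c1`: 51.7%

In a functional assay on the whole organism for inhibition, with Mus musculus as the target, with a stated time of 1 h, at a dose of 30 mg/kg by the intraperitoneal route (a lower number here means less inhibition, a higher number more inhibition at the dose given (going by the name of the read-out)), compound 1 stands highest of the three numbers: a number 13.9 percentage points lower from compound 1 to compound 3 (beyond the scatter), and a number 14.6 percentage points lower from compound 1 to compound 2 (beyond the scatter). Compound 2 and compound 3 differ only by bromo in place of chloro on an aromatic carbon, and that step was a number 0.7 percentage points higher from compound 2 to compound 3 (within the scatter), so the two halogens give the same picture. Compound 4, `COc1ccc(C(=O)/C=C/C2=Cc3ccccc3OC2)cc1`, is not yet measured. Its difference from compound 1 is methoxy in place of fluoro on an aromatic carbon. Among the compounds with values here, no measured step exchanges the fluoro for a methoxy, so the closest guides are the two steps away from compound 1, both modest drops. A modest drop beyond the scatter is therefore expected, a number 12.6 percentage points lower from compound 1 to compound 4 (beyond the scatter). Compound 4 is estimated at 53%, with a likely range from 38% to 68%.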

Compound 4, a percentage reported as inhibition, in the whole organism at one dose (the size of the read-out at that dose, not a potency): 66.2%
The estimate for compound 4 lay 13.2 percentage points below the measured number, within the range that was stated.
By their numbers in this assay, from the lowest: compounds 2 and 3 (each within the scatter of the next); then compounds 1 and 4 (each within the scatter of the next).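

At this position, para to a large group, methoxy in place of fluoro gave a number 0.6 percentage points higher from compound 1 to compound 4 (within the scatter), so the number held with two heavy atoms and a hydrogen-bond acceptor in place of a single fluorine. The earlier steps shown here away from compound 1 moved to a chloro or bromo at another place on the ring; this one keeps the place and changes only the group. No measurement here explains why the two groups match.

As far as these compounds go, whether an amine or a carboxylic acid at this position would hold the number remains open, as does how methoxy would behave where the chloro sits in compound 2.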